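A few compounds are considered here, and "the series" means these few. Any claim that something is new, unique, unknown or untested is made for them only; others in the source may bear on it.

Measured compounds in a functional assay on MKN-45 cells (Homo sapiens) for cytotoxicity; a lower number here means a stronger inhibitor, a higher number a weaker inhibitor:
- compound 1 `COc1ccc(S(=O)(=O)N2CCc3cc(Br)cc(NC(=O)c4ccco4)c32)cc1`: 78 nM
- compound 2 `COc1ccc(S(=O)(=O)N2CCc3cccc(NS(=O)(=O)c4ccc([N+](=O)[O-])cc4)c32)cc1`: 933 nM
- compound 3 `COc1ccc(S(=O)(=O)N2CCc3cccc(NS(=O)(=O)c4ccc(F)cc4)c32)cc1`: 890 nM

Compound 3 stands second highest of the three numbers. Among the measured compounds shown here, its nearest neighbour is compound 2, and the one step computed between measured compounds, a 1.0-fold lower number from compound 2 to compound 3 (0.02 log units; within the scatter), lies within the scatter, so the two values are read as the same. Compound 1 is furthest away; it differs from compound 3 in two places at once, so its value can only be set beside that of compound 3 without a step, and it shows the lowest number of the three.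

Compound 4 `COc1ccc(S(=O)(=O)N2CCc3cccc(NC(=O)C(C)(C)C)c32)cc1` has not been measured. It differs from compound 3 by (tert-butyl)carbonyl in place of (4-fluorophenyl)sulfonyl on a nitrogen on an aromatic ring. For the measured compounds named here, no measured step bears directly on this change: the one step known exchanges one substituent on the (4-fluorophenyl)sulfonyl group for another and leaves the sulfonyl itself in place. Going by the values given here, the only compound carrying a carbonyl on that nitrogen is compound 1, with 78 nM. Among the compounds with values here, compound 1 also carries a bromine, so it differs from compound 3 in two places, and no step between the two is available. The expectation is therefore a lower number for compound 4 than for compound 3, of moderate size, a 2.5-fold lower number from compound 3 to compound 4 (0.41 log units; beyond the scatter), with wide uncertainty. Compound 4 is estimated at 350 nM, in the range 90 nM to 1400 nM.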

Compound 4, half-maximal inhibitory concentration: 289 nM
Beside the measured number, compound 4's estimate is 1.2-fold (0.08 log units) above it; the measured number falls inside the stated range.
By their numbers in this assay, from the lowest: compound 1; then compound 4; then compounds 3 and 2 (each within the scatter of the next).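

At this nitrogen on an aromatic ring, exchanging the whole group matters more than exchanging a substituent on it: in this assay, the earlier step gives a 1.0-fold lower number from compound 2 to compound 3 (0.02 log units; within the scatter), whereas the new one gives a 3.1-fold lower number from compound 3 to compound 4 (0.49 log units; beyond the scatter). The (4-fluorophenyl)sulfonyl group is therefore not needed for cytotoxicity in this series, as compound 4 keeps a measurable effect with a (tert-butyl)carbonyl group, which contains no ring. No evidence is available that explains this step.

Compound 4 changes both the sulfonyl link and the group it carries, so the contributions of the carbonyl and the tert-butyl remain unseparated; a 4-fluorobenzoyl group or a tert-butylsulfonyl group on the same nitrogen would separate them. Also open, going by these compounds, is how this position responds to an acyl group carrying an amine or a carboxylic acid.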